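The compounds below may be only part of what the source reports. "The series", "measured", "known", "first", "only" and "open" are said of these compounds alone.

Compound 1, whose structure is `Cn1ncc(Cl)c1-c1cc(C(=O)N[C@@H]2CN[C@H](CCn3cncn3)C[C@H]2c2ccc(Cl)c(Cl)c2)oc1Cl`, gives 4.47 nM in an assay for inhibition of RAC-alpha serine/threonine-protein kinase (Homo sapiens), read by HTRF, with a stated time of 1 h; a lower number here means a stronger inhibitor, a higher number a weaker inhibitor. Of the two numbers in hand, compound 1 stands highest; the nearest is compound 3, `CC(=O)OCC[C@@H]1C[C@@H](c2ccc(F)c(F)c2)[C@H](NC(=O)c2cc(-c3c(Cl)cnn3C)c(Cl)o2)CN1`, which in this assay gives 3.4 nM, a gap within the scatter, so no order between compound 1 and compound 3 can be claimed. Compound 2, `O=C(N[C@@H]1CNCC[C@H]1c1ccc(Cl)cc1)c1ccc(-c2ncnc3c2CCC3O)s1`, is different in kind. In this assay compound 2 gives only a limit, > 1000 nM, and the limit of > 1000 nM in this assay, at which 1 of the 3 values shown sits, is where that limit for compound 2 sits. No pair of these compounds differs in one place only, so no measured step between them exists.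

Compound 4, `Cn1ncc(Cl)c1-c1cc(C(=O)N[C@@H]2CN[C@H](CC(=O)NCC(O)CO)C[C@H]2c2ccc(Cl)c(Cl)c2)oc1Cl`, is not yet measured; it differs from compound 1 in the change ((2,3-dihydroxypropyl)carbamoyl in place of (1H-1,2,4-triazol-1-yl)methyl on a saturated chain carbon bound to a saturated ring carbon). Among the compounds with values here, no measured step guides this change, and the expectation for compound 4 therefore rests on compound 1 alone. The step expected for compound 4 is a 1.8-fold higher number from compound 1 to compound 4 (0.25 log units; within the scatter), a small move toward a higher number that need not clear the scatter. Compound 4 is estimated at 8 nM in this assay, with a range expected from 2.5 nM to 30 nM.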

Compound 4, half-maximal inhibitory concentration: 3.13 nM
Estimate against measurement, compound 4: 2.6-fold (0.41 log units) above; the measured number falls inside the stated range.
By their numbers in this assay, from the lowest: compounds 4, 3 and 1 (each within the scatter of the next). At a limit, above all of these: compound 2.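

In this assay, putting (2,3-dihydroxypropyl)carbamoyl in place of (1H-1,2,4-triazol-1-yl)methyl on a saturated chain carbon bound to a saturated ring carbon gives a 1.4-fold lower number from compound 1 to compound 4 (0.15 log units; within the scatter), so the two compounds cannot be placed in any order. Within the data shown here, this is the only measured step at this place, and it shows that the number in this assay stays within the scatter even though the group that leaves holds a five-membered aromatic ring and no hydrogen-bond donors, while the group that enters holds no ring and does carry hydrogen-bond donors. Nothing measured here gives a reason for this result.

As far as these compounds go, both groups seen at this place carry no net charge, so it remains open whether a primary amine or a carboxylic acid on the same chain would keep the number within the scatter of these values. From the compounds shown here alone, it is also open whether the two hydroxyl groups of the new chain play any part in the number, which a plain propylcarbamoyl group at this place could test.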